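Replacing 4-hydroxyphenyl with 2,4-dichlorophenyl: an expected step

The compounds below may be only part of what the source reports. "The series", "measured", "known", "first", "only" and "open" are said of these compounds alone.

Values measured in a functional assay on HOP-92 cells (Homo sapiens) for inhibition, read by sulforhodamine B assay, with a stated time of 48 h (on this read-out lower numbers stand for stronger inhibition of growth and higher numbers for weaker inhibition of growth), are these:
Compound 1 `O=C(Cc1csc2nc(-c3ccc(Br)cc3)cn12)N/N=C/c1ccc(O)cc1` gives 19100 nM in this test
Compound 2 `COc1cccc(OC)c1/C=N/NC(=O)Cc1csc2nc(-c3ccc(Br)cc3)cn12` gives 13800 nM in this test

Compound 1, at 19100 nM here, sits level with compound 2 within the usual scatter. Among the compounds with values here, compound 3 `O=C(Cc1csc2nc(-c3ccc(Br)cc3)cn12)N/N=C/c1ccc(Cl)cc1Cl` has no measurement yet. It differs from compound 1 by one change, (2,4-dichlorophenyl in place of 4-hydroxyphenyl on a carbon with a double bond to nitrogen), namely 2,4-dichlorophenyl in place of 4-hydroxyphenyl on a carbon with a double bond to nitrogen. Within the data shown here, the one measured step at this place, a 1.4-fold lower number from compound 1 to compound 2 (0.14 log units; within the scatter), stayed within the scatter, so no step beyond the scatter is expected in this assay for this change. The expected step is a 1.5-fold lower number from compound 1 to compound 3 (0.17 log units; within the scatter) in size. For compound 3 the estimated value is 13000 nM with an expected range from 5000 nM to 32000 nM on repeat measurement.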

Compound 3, concentration for 50% growth inhibition: 28200 nM
Beside the measured number, compound 3's estimate is 2.2-fold (0.34 log units) below it, within the range that was stated.
By their numbers in this assay, from the lowest: compounds 2, 1 and 3 (each within the scatter of the next, the first and the last beyond it).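

In this assay, putting 2,4-dichlorophenyl in place of 4-hydroxyphenyl gives a 1.5-fold higher number from compound 1 to compound 3 (0.17 log units; within the scatter), so a group with no hydrogen-bond donors or acceptors is tolerated at this position. The comparison of the two substituted rings gives a 2.0-fold higher number from compound 2 to compound 3 (0.31 log units; beyond the scatter), the first difference at this position to pass the scatter, though only modestly. No evidence is available to explain this difference. On these data alone, all three compounds carry a six-membered aromatic ring of carbon only on the carbon with a double bond to nitrogen, so the effect of an amine, a carboxylic acid or a longer chain there remains open.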